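A larger ring on the amine nitrogen

A few compounds are considered here, and "the series" means these few. Any claim that something is new, unique, unknown or untested is made for them only; others in the source may bear on it.

In an ADME assay on liver (Homo sapiens) for metabolic stability, read by LC-MS, using microsomes and NADPH (a higher number here means that more of the compound is left, a lower number that less of the compound is left), compound 1 `Cc1cc(CN(CC2CC2)C(CC(=O)O)c2ccc(Cl)cc2)ccc1OCCN1C(=O)CCC1=O` gives 96% and compound 2 `Cc1cc(CN(CC2CC2)[C@@H](CC(=O)O)c2ccc(Cl)cc2)ccc1OCCN1C(=O)CCC1=O` gives 90%. The stereo step between them, a number 6 percentage points lower from compound 1 to compound 2 (within the scatter), does not touch the group that changes next. Compound 3 `CCCCN(Cc1ccc(OCCN2C(=O)CCC2=O)c(C)c1)C(CC(=O)O)c1ccc(Cl)cc1` gives 83%, which lies within the scatter of compound 2 but clearly under compound 1.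

Compound 4 `Cc1cc(CN(CC2CCCCC2)C(CC(=O)O)c2ccc(Cl)cc2)ccc1OCCN1C(=O)CCC1=O` carries cyclohexyl in place of propyl on a saturated chain carbon bound to an amine nitrogen. Among the compounds with values here, only one measured step changes this substituent: a number 13 percentage points lower from compound 1 to compound 3 (beyond the scatter), with propyl in place of cyclopropyl. There, the ring-bearing compound held the higher number, but cyclohexyl is a different ring, so this single modest step carries over only loosely. The expected change is therefore a number 3 percentage points lower from compound 3 to compound 4 (within the scatter), an estimate that stays within the scatter rather than marking a real step. Compound 4 is expected at 80%, with an estimated range from 62% to 93%.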

Compound 4, percent of the compound remaining: 47%
Compound 4: middle estimate off by 33 percentage points, on the high side; measured number below the stated range.
By their numbers in this assay, from the lowest: compound 4; then compounds 3, 2 and 1 (each within the scatter of the next, the first and the last beyond it).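

In this assay, within the data shown here, the group on this saturated chain carbon bound to an amine nitrogen proves far more decisive than the earlier compounds showed: cyclohexyl in place of propyl gives a number 36 percentage points lower from compound 3 to compound 4 (beyond the scatter) and cyclohexyl in place of cyclopropyl gives a number 49 percentage points lower from compound 1 to compound 4 (beyond the scatter). Among these compounds, the only earlier change of this group, with a number 13 percentage points lower from compound 1 to compound 3 (beyond the scatter), was modest, and the presence of a ring alone does not set the number here, as the cyclopropyl compound 1 and the cyclohexyl compound 4 stand furthest apart. Nothing given here accounts for the fall.

The compounds shown leave open at which ring size the number starts to fall, something a cyclobutyl or cyclopentyl group on this carbon would address. They also leave open whether a tetrahydropyranyl ring, with an oxygen in the ring, would behave as cyclohexyl does.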